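Swapping a Bromophenyl for a Methylphenyl in Weak Cytotoxins

The compounds below may be only part of what the source reports. "The series", "measured", "known", "first", "only" and "open" are said of these compounds alone.

Compound 1 `Fc1cccc(-c2nc(Nc3ccc(Cl)cc3)c3cc(F)ccc3n2)c1` in a functional assay on U-937 cells (Homo sapiens) for cytotoxicity, read by MTT assay, with a stated time of 48 h (on this read-out higher numbers stand for weaker inhibition and lower numbers for stronger inhibition), gives 32700 nM.
Compound 2 `Fc1cccc(-c2nc(Nc3ccccc3Cl)c3cc(F)ccc3n2)c1` in this assay reaches only > 50000 nM, which is a limit of the assay and not a number.
Compound 3 `Fc1cccc(-c2nc(Nc3ccc(Br)cc3)c3cc(F)ccc3n2)c1` in this assay likewise reaches only > 50000 nM, again a limit and not a number.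

Compound 3 thus stands at the limit of > 50000 nM in this assay, at which 2 of the 3 values shown sit, without a number of its own. Compound 4 `Cc1cccc(Nc2nc(-c3cccc(F)c3)nc3ccc(F)cc23)c1` differs from it in one place: 3-methylphenyl in place of 4-bromophenyl on a nitrogen on an aromatic ring. The measured steps are an at least 1.5-fold higher number from compound 1 to compound 2 (0.18 log units; that floor lies within the scatter) and an at least 1.5-fold higher number from compound 1 to compound 3 (0.18 log units; that floor lies within the scatter), both floors lying within the scatter, and a step that the two limits leave unreadable from compound 2 to compound 3. Within the data shown here, none of them exchanges a halogen for a methyl, so they give no direction for this change; they show only that every measured compound is weak. Compound 4 is therefore expected to remain weak, with an estimated step of a number no higher from compound 3 to compound 4 (the limit leaves the size open) meaning no change beyond the scatter. The estimate for compound 4 is 50000 nM, expected to lie between 20000 nM and 120000 nM, with a fair chance that only a limit is reported.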

Compound 4, half-maximal inhibitory concentration: > 50000 nM
Compound 4 gave a limit, no number; the forecaster's own chance of this, stated with the estimate: 60%; the middle value sits exactly at the limit.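

Compound 4 shows that a 3-methylphenyl on this nitrogen, with no halogen on the ring, leaves the compound as weak in this assay as the bromo compound appears, and its result is a limit of the assay, not a number: (the limit of > 50000 nM in this assay, at which 3 of the 4 values shown sit). Among these compounds, the only step that can be read (an at least 1.5-fold higher number from compound 1 to compound 4 (0.18 log units; that floor lies within the scatter)) gives no firm difference. The steps to compound 2 and compound 3 cannot be read.

On these data alone, how far beyond the limit these compounds lie stays open. So does whether an amine or a carboxylic acid on this phenyl ring would bring real strength.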